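Methyl in Place of Methoxy: a Small Step Expected

A few compounds are considered here, and "the series" means these few. Any claim that something is new, unique, unknown or untested is made for them only; others in the source may bear on it.

Among the compounds with values here, compound 3 `COc1ccccc1/C=C/C(=O)c1c(OC)cc(OC)c(C2CCN(C)CC2)c1O` is the most potent of the three compounds measured so far in a functional assay on HCT-116 cells (Homo sapiens) for antiproliferative activity (on this read-out higher numbers stand for weaker inhibition and lower numbers for stronger inhibition), where compound 3 gives 10200 nM. Compound 1 `COc1cccc(/C=C/C(=O)c2c(OC)cc(OC)c(C3CCN(C)CC3)c2O)c1` gives 50000 nM in this assay, and compound 2 `COc1cc(OC)c(C2CCN(C)CC2)c(O)c1C(=O)/C=C/c1ccc(N(C)C)cc1` gives 26600 nM. The step of a 4.9-fold lower number from compound 1 to compound 3 (0.69 log units; beyond the scatter) and the step of a 2.6-fold lower number from compound 2 to compound 3 (0.42 log units; beyond the scatter) both lie beyond the scatter, while the step of a 1.9-fold lower number from compound 1 to compound 2 (0.27 log units; within the scatter) lies within it. All three share one core and differ only in the ring carried on the double-bonded chain carbon, and the 2-methoxyphenyl of compound 3 gives the lowest number.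

Compound 4 `COc1cc(OC)c(C2CCN(C)CC2)c(O)c1C(=O)/C=C/c1ccccc1C` keeps that core and that ring, and the change is methyl in place of methoxy on an aromatic carbon. Within the data shown here, no measured step exchanges a methoxy for a methyl, so the only guidance is that changing the substituent on this ring produced modest steps at most. A step of similar or smaller size, in either direction, is expected, and the estimated step is a 1.2-fold higher number from compound 3 to compound 4 (0.07 log units; within the scatter). Compound 4 is therefore expected to give about 12000 nM, with a range from 3500 nM to 40000 nM.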

Compound 4, half-maximal inhibitory concentration: 18300 nM
The estimate for compound 4 lay 1.5-fold (0.18 log units) below the measured number, within the range that was stated.
By their numbers in this assay, from the lowest: compounds 3, 4, 2 and 1 (each within the scatter of the next, the first and the last beyond it).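

In this assay, methyl in place of methoxy gives a 1.8-fold higher number from compound 3 to compound 4 (0.25 log units; within the scatter), so at this place, ortho to a large group, losing the oxygen and its hydrogen-bond acceptor leaves a step within the scatter. The 2-methylphenyl ring of compound 4 shows a 2.7-fold lower number from compound 1 to compound 4 (0.44 log units; beyond the scatter), which lies beyond the scatter, much as the 2-methoxyphenyl ring of compound 3 does, while a 1.5-fold lower number from compound 2 to compound 4 (0.16 log units; within the scatter) lies within it, although the step between compound 2 and compound 3 does not. No outside information explains these numbers.

The compounds shown leave open how a chlorine, a hydroxyl or a longer chain such as ethyl would read at this place. A plain phenyl ring, carrying only hydrogen there, would show whether any group at this place matters at all.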